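The source may report more compounds than this note shows. Statements on the series, on what has been measured and on what is new or still open speak of the compounds shown alone.

In a functional assay on QGY-7703 cells (Homo sapiens) for cytotoxicity, read by MTT assay, with a stated time of 24 h (on this read-out higher numbers stand for weaker inhibition and lower numbers for stronger inhibition), compound 1 `CN1C/C(=C\c2ccncc2)C(=O)/C(=C/c2ccccc2F)C1` gives 4900 nM. Compound 2 `Cc1ccc(S(=O)(=O)N2C/C(=C\c3ccncc3)C(=O)/C(=C/c3ccccc3F)C2)cc1` carries (4-methylphenyl)sulfonyl in place of methyl on an amine nitrogen in a ring. In this assay, going by these compounds, compound 2 is reported only as a limit, > 20000 nM, so its exact standing is unknown. Compound 3 `O=C1/C(=C/c2ccncc2)CN(S(=O)(=O)c2ccc(F)cc2)C/C1=C\c1ccccc1F` keeps the sulfonyl group and changes one place on its aromatic ring: fluoro in place of methyl on an aromatic carbon. This is fluoro in place of methyl on an aromatic carbon, para to a large group, turning 4-methylphenyl into 4-fluorophenyl. Among the measured compounds shown here, only one measured step bears on it, and only indirectly: an at least 4.0-fold higher number from compound 1 to compound 2 (0.61 log units; beyond the scatter). For the measured compounds named here, that step changes the group on the nitrogen, and no measured step shows what this exchange of methyl for fluoro does. Compound 3 retains the sulfonyl group introduced in an at least 4.0-fold higher number from compound 1 to compound 2 (0.61 log units; beyond the scatter), so it is expected to remain weak in this assay, and a further limit would be no surprise. The expected step, an at least 1.2-fold lower number from compound 2 to compound 3 (0.09 log units; that floor lies within the scatter), is not expected to lie beyond the scatter. For compound 3 the estimated value is 16000 nM, with an expected range from 5000 nM to 40000 nM.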

Compound 3, half-maximal inhibitory concentration: 9100 nM
Estimate against measurement, compound 3: 1.8-fold (0.25 log units) above; the measured number falls inside the stated range.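

In this assay, the exchange of methyl for fluoro, on an aromatic carbon para to a large group, gives an at least 2.1-fold lower number from compound 2 to compound 3 (0.34 log units; beyond the scatter). The aromatic ring of the sulfonyl group is therefore not a silent place, since a change of a single heavy atom there moves the reading beyond the scatter, which the step from the methyl amine to the sulfonyl compound could not show. The sulfonyl group on the ring nitrogen also does not by itself fix a weak reading, as the comparison with the methyl compound now gives a 1.9-fold higher number from compound 1 to compound 3 (0.27 log units; within the scatter), which leaves compound 3 and compound 1 within the scatter of each other. The size of the fluoro step has only a floor, as compound 2 is reported as a limit: the limit of > 20000 nM in this assay, at which 1 of the 3 values shown sits.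

Going by these compounds, whether chloro, methoxy or a plain hydrogen at this same place would read like fluoro or like methyl remains open, so the shift cannot yet be assigned to the arrival of fluoro rather than the departure of methyl. Also open, on these data alone, is how a sulfonyl group carrying a short alkyl chain instead of the aromatic ring would compare on the ring nitrogen of the shared core.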